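Changing One Aryl Group on a Pyridazinone Amide

This account rests on a few compounds, and the source may have more. Where it says the series, first, only, none or still open, it means among the compounds named here.

Compound 1, `Cc1cc(=O)n(-c2cccc(F)c2)nc1C(=O)Nc1ccc(Oc2ncnc3[nH]ccc23)c(F)c1`, gives 31500 nM in a functional assay on A549 cells (Homo sapiens) for cytotoxicity, read by MTT assay, with a stated time of 72 h; a lower number here means a stronger inhibitor, a higher number a weaker inhibitor.
Compound 2, `Cc1ccc(-n2nc(C(=O)Nc3ccc(Oc4ncnc5[nH]ccc45)c(F)c3)c(C)cc2=O)cc1`, gives 18500 nM.
Compound 3, `Cc1cc(=O)n(-c2cccc(F)c2)nc1C(=O)Nc1ccc(Oc2ncnc3c2ccn3C)cc1`, gives 23400 nM.

Compound 4, `Cc1ccc(-n2nc(C(=O)Nc3ccc(Oc4ncnc5c4ccn5C)cc3)c(C)cc2=O)cc1`, has not yet been tested. It differs from compound 3 by 4-methylphenyl in place of 3-fluorophenyl on an aromatic nitrogen. The same change, (4-methylphenyl in place of 3-fluorophenyl on an aromatic nitrogen), separates compound 1 from compound 2 and gave a 1.7-fold lower number from compound 1 to compound 2 (0.23 log units; within the scatter). Compound 1 and compound 3 carry different cores, and the difference between the two cores is not broken down here; their numbers sit close to each other, as do those of compound 2 and compound 3. Compound 4 is expected to give about 14000 nM, in a range from 6000 nM to 35000 nM. Among the compounds with values here, that estimate means an expected step of a 1.7-fold lower number from compound 3 to compound 4 (0.22 log units; within the scatter), resting only on the one earlier instance, a 1.7-fold lower number from compound 1 to compound 2 (0.23 log units; within the scatter), which itself was small.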

Compound 4, half-maximal inhibitory concentration: > 60000 nM
Compound 4: no number, only a limit; the forecaster's own chance of this, stated with the estimate: 5%; middle value at least 4.2-fold (0.63 log units) from the limit.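

In this assay compound 4 gives > 60000 nM, which is a limit of the assay and not a number. Within the data shown here, replacing 3-fluorophenyl with 4-methylphenyl here gives an at least 2.5-fold higher number from compound 3 to compound 4 (0.40 log units; beyond the scatter), so the earlier step does not carry over as a fixed shift between these two cores: the same change on two cores in this assay, a 1.7-fold lower number (0.23 log units; within the scatter) from compound 1 to compound 2 and an at least 2.5-fold higher number (0.40 log units; beyond the scatter) from compound 3 to compound 4, at least 4.3-fold (0.64 log units) apart, beyond the scatter of two such steps With only one pair on each core, this shows that the outcome of the change depends on its setting in these four compounds, but it does not show which part of the cores matters or how any other core would respond.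

The compounds shown leave open how both cores would respond to other groups on that aromatic nitrogen, such as an unsubstituted phenyl or a 4-aminophenyl. Going by these compounds, the full size of the step from the core of compound 3 also remains open, since only a limit stands for compound 4.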